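Ether-to-thioether swap on the amide side chain

The compounds below may be only part of what the source reports. "The series", "measured", "known", "first", "only" and "open" are said of these compounds alone.

Measured so far:
compound 1, `O=C(COCc1ccccc1)N1CCN(c2ccccc2)CC1`: 7100 nM
compound 2, `O=C(COCc1ccccc1)N1CCN(c2ccncc2)CC1`: limit, > 25000 nM
compound 3, `O=C(COCc1cccnc1)N1CCN(c2ccc(Cl)cc2Cl)CC1`: 1090 nM

In a functional assay on HEK293 cells for positive allosteric modulation of metabotropic glutamate receptor 5 (Homo sapiens), read by FLIPR and calcium flux (a lower number here means that less compound is needed, a higher number that more compound is needed for the effect), compound 3 gives 1090 nM, the lowest of the two numbers shown. Compound 1 gives 7100 nM in this assay, a higher number than compound 3. For compound 2 this assay reports only a limit, > 25000 nM; that is the limit of > 25000 nM in this assay, at which 1 of the 3 values shown sits, and not a number.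

Compound 4, `O=C(CSCc1ccccc1)N1CCN(c2ccc(Cl)cc2Cl)CC1`, is not yet measured. It differs from compound 3 by benzylsulfanyl in place of (pyridin-3-yl)methoxy on a saturated chain carbon bound to a carbonyl carbon. Among the measured compounds shown here, the only measured step, an at least 3.5-fold higher number from compound 1 to compound 2 (0.54 log units; beyond the scatter), concerns a change on the amine nitrogen of the shared core, not the chain carbon changed here, so no measured step bears directly on the present change. With nothing to set a direction, a step of the size of the scatter or a modest improvement is expected for compound 4, a 1.4-fold lower number from compound 3 to compound 4 (0.13 log units; within the scatter). Compound 4 is estimated at 800 nM in this assay, within 250 nM to 3000 nM.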

Compound 4, half-maximal effective concentration: 7100 nM
Compound 4: middle estimate off by 8.9-fold (0.95 log units), on the low side; measured number above the stated range.
By their numbers in this assay, from the lowest: compound 3; then compounds 1 and 4 (each within the scatter of the next). At a limit, above all of these: compound 2.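

In this assay, the saturated chain carbon bound to the carbonyl carbon is a place where the series responds, which the earlier step on the amine nitrogen could not show: benzylsulfanyl in place of (pyridin-3-yl)methoxy gives a 6.5-fold higher number from compound 3 to compound 4 (0.81 log units; beyond the scatter). The change is not a single-atom edit, as the ring loses its hetero atom and the linking oxygen gives way to sulfur in the same step. Nothing at hand accounts for this step.

Which of these two differences carries the step stays open. A benzyloxy or a (pyridin-3-yl)methylsulfanyl group at this place on the core of compound 3 would separate them, and a longer chain between the sulfur and the ring would test how far the place tolerates extension.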